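Switching the acyl chain of compound 3 toward the benzylpropanoyl pattern

This account rests on a few compounds, and the source may have more. Where it says the series, first, only, none or still open, it means among the compounds named here.

Compound 3 `CC(C)C[C@H](N)c1cc(C(F)(F)F)ccc1N1CCN(C(=O)CC(C)C(=O)c2ccc(Cl)cc2)CC1` gives 1100 nM in an assay on HEK293 cells for displacement of a labelled ligand from Melanocortin receptor 4 (Homo sapiens) (on this read-out lower numbers stand for stronger inhibition and higher numbers for weaker inhibition), the highest of the three numbers; compound 2 `Cc1ccc(N2CCN(C(=O)[C@H](C)Cc3ccc(Cl)cc3F)CC2)c([C@@H](N)CC(C)C)c1` gives 20 nM and compound 1 `COc1cc(Cl)ccc1C[C@@H](C)C(=O)N1CCN(c2ccc(C)cc2[C@@H](N)CC(C)C)CC1` gives 8.1 nM. Compound 4 `COc1ccc(CC(C)C(=O)N2CCN(c3ccc(C(F)(F)F)cc3[C@@H](N)CC(C)C)CC2)cc1F` differs from compound 3 by 1-(3-fluoro-4-methoxybenzyl)ethyl in place of 2-((4-chlorophenyl)carbonyl)propyl on a carbonyl carbon. Among the compounds with values here, no measured step matches this change directly. Within the data shown here, the only step, a 2.5-fold higher number from compound 1 to compound 2 (0.39 log units; beyond the scatter), concerns a ring substituent within the chain type that compound 4 adopts; both compound 1 and compound 2 carry that chain type and sit far lower than compound 3. A large drop toward their range is therefore expected, tempered by the trifluoromethyl on the shared core of compound 4. Expected: a 28-fold lower number from compound 3 to compound 4 (1.44 log units; beyond the scatter), giving compound 4 an estimated 40 nM (range 10 nM to 160 nM).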

Compound 4, inhibition constant: 200 nM
For compound 4 the middle estimate is 5.0-fold (0.70 log units) below the measured one, and the stated range ends below it.
By their numbers in this assay, from the lowest: compound 1; then compound 2; then compound 4; then compound 3.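

On a carbonyl carbon whose other neighbours are the amide-type nitrogen in a ring, 1-(3-fluoro-4-methoxybenzyl)ethyl in place of 2-((4-chlorophenyl)carbonyl)propyl gives a 5.5-fold lower number from compound 3 to compound 4 (0.74 log units; beyond the scatter) in this assay on the trifluoromethyl-bearing core. The step comes with no change in heavy-atom count, and each chain keeps its one aromatic ring. No measurement here bears on why the number moves.

Compound 4 differs from compound 1 and compound 2 in more than one place, so the contribution of the trifluoromethyl stays unresolved. On these data alone, how a nitrile or a longer chain would fare at this carbonyl carbon remains open.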